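The compounds below may be only part of what the source reports. "The series", "measured", "known", "first", "only" and "open" are said of these compounds alone.

Measured so far in a functional assay on KB cells (Homo sapiens) for antiproliferative activity, read by sulforhodamine B assay, with a stated time of 48 h; a higher number here means a weaker inhibitor of growth, a lower number a stronger inhibitor of growth:
- Compound 1 `COc1ccc(S(=O)(=O)Nc2ccc(CCc3ccc(C(=O)Nc4ccccc4N)cc3)cc2)cc1`: > 10000 nM (a limit of the assay, not a number)
- Compound 2 `COc1ccc(S(=O)(=O)Nc2ccccc2CCc2ccc(C(=O)Nc3ccccc3N)cc2)cc1`: 23 nM
- Compound 3 `COc1ccc(S(=O)(=O)Nc2ccccc2CCc2ccc(C(=O)NO)cc2)cc1`: > 10000 nM (a limit of the assay, not a number)

Only compound 2 has a true number (23 nM), so it cannot be ranked within a spread of exact values. The other results stand at the limit of > 10000 nM in this assay, at which 2 of the 3 values shown sit.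

The next compound is compound 4 `COc1cccc(S(=O)(=O)Nc2ccccc2CCc2ccc(C(=O)Nc3ccccc3N)cc2)c1`, which keeps the core of compound 2 and moves one group: 3-methoxyphenyl in place of 4-methoxyphenyl on a sulfonyl sulfur. The two compounds have the same atoms, joined differently.

For the measured compounds named here, no measured step touches this group, so there is no direct guide to the size of the change. Going by the values given here, the only measured step is an at least 430-fold higher number from compound 2 to compound 3 (2.63 log units; beyond the scatter), and it lies at a different place, hydroxy in place of 2-aminophenyl on an amide-type nitrogen. Among the compounds with values here, it shows only that a single change in this small set can be very large. A moderate loss of growth inhibition therefore seems the most reasonable expectation in this assay, with wide uncertainty.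

The expected change is a 5.2-fold higher number from compound 2 to compound 4 (0.72 log units; beyond the scatter), towards a higher number.

For compound 4 the estimated value is 120 nM, with an expected range from 20 nM to 2000 nM.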

Compound 4, concentration for 50% growth inhibition: 462 nM
Compound 4: the middle estimate sits 3.9-fold (0.59 log units) below what was measured; low and high end bracket the measured number.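

In this assay, the placing of the methoxy group on the ring carried by the sulfonyl sulfur clearly matters: with the same atoms joined differently, 3-methoxyphenyl in place of 4-methoxyphenyl gives a 20-fold higher number from compound 2 to compound 4 (1.30 log units; beyond the scatter). For the compounds shown here, this is the first measured change at this part of the molecule, since the only earlier step, an at least 430-fold higher number from compound 2 to compound 3 (2.63 log units; beyond the scatter), lay at the amide-type nitrogen, and it shows that a move of one group, with no atom gained or lost, can also produce a large loss of growth inhibition. Even so, compound 4 keeps a true number and does not join the results that stand at the limit: the limit of > 10000 nM in this assay, at which 2 of the 4 values shown sit.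

The compounds shown leave open whether the methoxy group itself contributes to growth inhibition or whether 4-methoxyphenyl simply suits this place better than 3-methoxyphenyl, a question that a plain phenyl ring could help to settle. They also leave open how other groups at the same place would compare, such as 4-methylphenyl, 4-chlorophenyl or 4-ethoxyphenyl, and so how much room this position allows.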